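Amide-nitrogen aryl variation: compound 3 toward compound 4

The source may report more compounds than this note shows. Statements on the series, on what has been measured and on what is new or still open speak of the compounds shown alone.

Compound 3 `Cc1ccc(OCC(=O)N(Cc2cccs2)c2cn[nH]c2)cc1` stands lowest of the three numbers in an assay on HEK293 cells for agonist activity at transient receptor potential cation channel subfamily M member 8 (Homo sapiens), read by fluorescence and calcium flux, with a stated time of 15 min (a higher number here means that more compound is needed for the effect, a lower number that less compound is needed), where compound 3 gives 1.4 nM. Compound 2 `Cc1ccc(OCC(=O)N(Cc2cccs2)c2ccccc2)cc1` gives 23 nM and compound 1 `Cc1ccc(OCC(=O)N(Cc2cccs2)c2ccccn2)cc1` gives 200 nM; between the two weaker members the step is an 8.7-fold lower number from compound 1 to compound 2 (0.94 log units; beyond the scatter). Compound 4 `Cc1ccc(OCC(=O)N(Cc2cccs2)c2ccon2)cc1` differs from compound 3 by 1,2-oxazol-3-yl in place of 1H-pyrazol-4-yl on an amide-type nitrogen. Within the data shown here, no measured step exchanges one five-membered aromatic ring for another. Among the measured compounds shown here, the steps that bear on it, a 16-fold lower number from compound 2 to compound 3 (1.22 log units; beyond the scatter) and a 140-fold lower number from compound 1 to compound 3 (2.15 log units; beyond the scatter), show that the 1H-pyrazol-4-yl group sets compound 3 apart from both phenyl and pyridin-2-yl, so the replacement is expected to give back part of that gain, a step of an 11-fold higher number from compound 3 to compound 4 (1.03 log units; beyond the scatter) in this assay. Compound 4 is therefore estimated at 15 nM, range 3 nM to 80 nM.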

Compound 4, half-maximal effective concentration: 2 nM
Estimate against measurement, compound 4: 7.5-fold (0.88 log units) above; the whole stated range lies above it.
By their numbers in this assay, from the lowest: compounds 3 and 4 (each within the scatter of the next); then compound 2; then compound 1.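

In this assay the position on the amide-type nitrogen takes 1,2-oxazol-3-yl in place of 1H-pyrazol-4-yl without a change beyond the scatter (a 1.4-fold higher number from compound 3 to compound 4 (0.15 log units; within the scatter)), although the entering ring has 0 hydrogen-bond donors and the leaving ring 1. The low number is thus not unique to 1H-pyrazol-4-yl, as 1,2-oxazol-3-yl also stands clear of phenyl (a 12-fold lower number from compound 2 to compound 4 (1.06 log units; beyond the scatter)) and pyridin-2-yl (a 100-fold lower number from compound 1 to compound 4 (2.00 log units; beyond the scatter)). No evidence on the origin of these steps is available.

Still open, going by these compounds, is whether a five-membered aromatic ring with a single hetero atom, such as thiophen-3-yl, keeps this level. The same holds for a saturated group such as cyclopropyl at this position.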